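A few compounds are considered here, and "the series" means these few. Any claim that something is new, unique, unknown or untested is made for them only; others in the source may bear on it.

Measured in a functional assay on the whole organism (strain Kunming) with Mus musculus as the target; on this read-out higher numbers stand for an effect only at larger amounts of compound and lower numbers for an effect already at smaller amounts:
compound 1 `O=C1CC(c2cccc(Cl)c2)n2ncnc2N1` gives 47.3 mg/kg
compound 2 `O=C1CC(c2cccc(Br)c2)n2ncnc2N1` gives 84.9 mg/kg
compound 3 `O=C1CC(c2ccccc2Cl)n2nccc2N1` gives 63.4 mg/kg

Compound 4 `O=C1CC(c2ccccc2Br)n2nccc2N1` has not yet been measured in this assay. Compound 1 and compound 2 differ by bromo in place of chloro on an aromatic carbon. Compound 3 and compound 4 differ by bromo in place of chloro on an aromatic carbon. This is the same kind of change, but not the same change: in the first pair the halogen sits meta to a large group, in the second pair ortho to a large group. How the core of compound 1 and the core of compound 3 differ is not broken down here; in this assay compound 3 lies within the scatter of both compound 1 and compound 2. The measured step was a 1.8-fold higher number from compound 1 to compound 2 (0.25 log units; within the scatter). Resting on that step, compound 4 is expected to show a 1.5-fold higher number from compound 3 to compound 4 (0.18 log units; within the scatter) in this assay, again within the scatter. For compound 4 the estimate is 95 mg/kg, with a range from 45 mg/kg to 200 mg/kg.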

Compound 4, dose for half-maximal effect: 39.4 mg/kg
Compound 4: the middle estimate sits 2.4-fold (0.38 log units) above what was measured; measured number below the stated range.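

In this assay, putting bromo in place of chloro on the core of compound 3 gave a 1.6-fold lower number from compound 3 to compound 4 (0.21 log units; within the scatter), while the same change on the core of compound 1 gave a 1.8-fold higher number from compound 1 to compound 2 (0.25 log units; within the scatter). Each step alone is within the scatter, but set side by side they do not agree, so the result of this change did not carry from one core to the other here: the same change on two cores in this assay, a 1.8-fold higher number (0.25 log units; within the scatter) from compound 1 to compound 2 and a 1.6-fold lower number (0.21 log units; within the scatter) from compound 3 to compound 4, 2.9-fold (0.46 log units) apart, beyond the scatter of two such steps This does not show what sets the two steps apart, since the two pairs differ both in the core and in where the halogen sits.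

The compounds shown leave open how a methoxy group, a nitrile or an amine would read at the place of the halogen in this assay. Also open, on these data alone, is how bromo and chloro compare on the core of compound 1 when ortho to a large group.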